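The compounds below may be only part of what the source reports. "The series", "measured", "known", "first", "only" and "open" are said of these compounds alone.

Two close relatives of a shared core have been tested in an assay on CHO cells for displacement of a labelled ligand from adenosine receptor A1 (Homo sapiens), with a stated time of 60 min, tested at 10 uM; on this read-out higher numbers stand for more inhibition at the one concentration tested (going by the name of the read-out) and lower numbers for less inhibition. Compound 1, `CCOC(=O)C1=C(C)N(C)C(=O)NC1c1ccco1`, gives 17%, and compound 2, `CCOC(=O)C1=C(C)N(C)C(=O)NC1c1ccoc1`, gives 17%. Among the compounds with values here, the only step between them is no change at the digits printed from compound 1 to compound 2 (within the scatter), so compound 2 stands level with compound 1 on this read-out, and neither number can be called the higher of the two. Compound 3, `CCOC(=O)C1=C(C)N(C)C(=O)NC1c1ccsc1`, has not yet been measured. It differs from compound 2 in one place: thiophen-3-yl in place of furan-3-yl on a saturated ring carbon. Within the data shown here, the single measured step bears on this only loosely: changing furan-2-yl to furan-3-yl left the read-out unchanged, but no measured pair shows what exchanging a furan for a thiophene does. Given that the one step on record, no change at the digits printed from compound 1 to compound 2 (within the scatter), brought no change, and that the ring that enters matches the ring that leaves in size and in its count of hydrogen-bond acceptors, the step of a number 3 percentage points higher from compound 2 to compound 3 (within the scatter) is expected to stay within the scatter. Compound 3 is therefore estimated to give 20% in this assay, with a range from 5% to 45%.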

Compound 3, a percentage reported as inhibition, at one concentration (the size of the read-out at that concentration, not a potency): 30%
Beside the measured number, compound 3's estimate is 10 percentage points below it, and the stated range covers the measured number.
By their numbers in this assay, from the lowest: compounds 1 and 2 (each within the scatter of the next); then compound 3.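

Moving the attachment point on the furan had shown nothing at this saturated ring carbon, whereas exchanging the furan for a thiophene produces a clear difference in this assay, with a number 13 percentage points higher from compound 2 to compound 3 (beyond the scatter) on the read-out. The comparison with the other furan points the same way, with a number 13 percentage points higher from compound 1 to compound 3 (beyond the scatter) on the read-out, so thiophen-3-yl stands apart from both furan groups, even though it matches furan-3-yl in heavy atoms, ring size and hydrogen-bond acceptors. This position therefore responds to more than those counted features, but no supporting measurement is available to say what lies behind the difference.

The compounds shown leave open whether thiophen-2-yl would behave like thiophen-3-yl, and whether a phenyl ring, or a ring carrying an amine or a carboxylic acid, would move the number further at this carbon. They also leave open how much of this difference would carry over to a true potency, since each number is a reading at one concentration and does not itself measure potency.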